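A few compounds are considered here, and "the series" means these few. Any claim that something is new, unique, unknown or untested is made for them only; others in the source may bear on it.

Measured compounds, read-out in an assay (Cavia porcellus) for displacement of a labelled ligand from Sigma non-opioid intracellular receptor 1 (Homo sapiens); on this read-out lower numbers stand for stronger inhibition and higher numbers for weaker inhibition:
compound 1 `CC(=O)OC(CCCN1CCN(c2ncc(F)cn2)CC1)c1ccc(F)cc1` gives 227 nM
compound 2 `Fc1ccc(CCCCN2CCN(c3ncc(F)cn3)CC2)cc1` gives 23 nM
compound 3 `Fc1ccc(OCCCN2CCN(c3ncc(F)cn3)CC2)cc1` gives 89 nM

Compound 3 stands second highest of the three numbers in this assay; its nearest neighbour is compound 1, its furthest compound 2. Compound 4 `NC(CCCN1CCN(c2ncc(F)cn2)CC1)C1CCCCC1` has not yet been measured in this assay. It differs from compound 3 in one place: amino(cyclohexyl)methyl in place of 4-fluorophenoxy on a saturated chain carbon, three bonds along the chain from an amine nitrogen in a ring.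

Two measured steps are at hand. The step from compound 1 to compound 2, removal of an oxygen-bearing group from the chain carbon bound to the aromatic ring, gave a 9.9-fold lower number from compound 1 to compound 2 (0.99 log units; beyond the scatter). The step from compound 2 to compound 3, insertion of an oxygen into the chain between ring and piperazine, gave a 3.9-fold higher number from compound 2 to compound 3 (0.59 log units; beyond the scatter). Neither step swaps an aromatic ring for a saturated one, and none adds a hydrogen-bond donor, so the new change is only partly covered. The shared piperazine and the chain length are kept. Taken together, a modest step to a lower number is expected for compound 4, a 1.8-fold lower number from compound 3 to compound 4 (0.25 log units; within the scatter), with wide uncertainty. Compound 4 is estimated at 50 nM, between 10 nM and 250 nM.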

Compound 4, half-maximal inhibitory concentration: 52 nM
For compound 4 the middle estimate is 1.0-fold (0.02 log units) below the measured one; measured number inside the range.
By their numbers in this assay, from the lowest: compound 2; then compounds 4 and 3 (each within the scatter of the next); then compound 1.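

Replacing 4-fluorophenoxy with amino(cyclohexyl)methyl on this saturated chain carbon in this assay gives a 1.7-fold lower number from compound 3 to compound 4 (0.23 log units; within the scatter) and so shows that this position tolerates a non-aromatic ring of carbon only and a hydrogen-bond donor, at least in this one compound. Against the 4-fluorobenzyl of compound 2, the same group gives a 2.3-fold higher number from compound 2 to compound 4 (0.35 log units; beyond the scatter) and so leaves a real gap to that compound. No measurement shown here explains either step.

From the compounds shown here alone, the ring and the amine enter together, so their separate contributions to the number of compound 4 remain open. A plain cyclohexylmethyl group and amino(4-fluorophenyl)methyl at this carbon would separate the two, and the effect of a carboxylic acid here is also unknown.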